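Compound 3 Follows a Step Within the Scatter

The compounds below may be only part of what the source reports. "The series", "measured", "known", "first", "only" and "open" are said of these compounds alone.

Compounds and their values in an ADME assay on microsomes from liver (Homo sapiens) for pharmacokinetics (on this read-out higher numbers stand for fast clearance and lower numbers for slow clearance), so far
compound 1 `COc1cccc(C(=O)NCCNC(=O)[C@H](CC(=O)NC(C)(C)C)NS(=O)(=O)c2ccc(C)cc2)c1` gives 202 mL.min-1.g-1
compound 2 `Cc1ccc(S(=O)(=O)N[C@@H](CC(=O)NC(C)(C)C)C(=O)NCCNC(=O)c2ccccc2F)cc1` gives 141 mL.min-1.g-1
compound 3 `C#Cc1cccc(C(=O)NCCNC(=O)[C@H](CC(=O)NC(C)(C)C)NS(=O)(=O)c2ccc(C)cc2)c1` has no value yet

Among the measured compounds shown here, compound 2 stands within the scatter of compound 1, the only other compound measured. The next change leads to compound 3 and is described by 3-ethynylphenyl in place of 2-fluorophenyl on a carbonyl carbon in the form of 3-ethynylphenyl in place of 2-fluorophenyl on a carbonyl carbon. For the measured compounds named here, no measured compound carries the 3-ethynylphenyl group. Going by the values given here, the one relevant measurement is for compound 1 and compound 2, which changes the group at the same place with a 1.4-fold lower number from compound 1 to compound 2 (0.16 log units; within the scatter) as its result. On that slim evidence, no step beyond the scatter is expected in this assay and no direction can be favoured. The estimated change is a 1.2-fold higher number from compound 2 to compound 3 (0.08 log units; within the scatter) for this replacement. Compound 3 is expected to give 170 mL.min-1.g-1 with an estimated range from 80 mL.min-1.g-1 to 340 mL.min-1.g-1 in this measurement.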

Compound 3, intrinsic clearance in microsomes: 61 mL.min-1.g-1
Compound 3: middle estimate off by 2.8-fold (0.45 log units), on the high side, and the stated range ends above it.
By their numbers in this assay, from the lowest: compound 3; then compounds 2 and 1 (each within the scatter of the next).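

The earlier pair had shown no step beyond the scatter at this position, but the group on the carbonyl carbon can in fact shift the number in this assay: the 3-ethynylphenyl group brings a 2.3-fold lower number from compound 2 to compound 3 (0.36 log units; beyond the scatter) and, with ethynyl in place of methoxy on an aromatic carbon, a 3.3-fold lower number from compound 1 to compound 3 (0.52 log units; beyond the scatter) as well. Both steps are modest, yet together they set compound 3 apart from compound 1 and compound 2, which remain within the scatter of each other. Nothing available explains why the number falls with this group.

The compounds shown leave open whether the step belongs to the triple bond itself, since no nitrile or propynyl group appears at this place for comparison. They also leave open whether a larger group, such as a 3-phenylethynylphenyl group, would keep the lower number.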